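This account rests on a few compounds, and the source may have more. Where it says the series, first, only, none or still open, it means among the compounds named here.

In a functional assay on MDA-MB-231 cells (Homo sapiens) for antiproliferative activity, read by MTT assay (on this read-out lower numbers stand for stronger inhibition and higher numbers for weaker inhibition), compound 2 `CC/C=C\C/C=C\C/C=C\CCCCCCCc1cc(=O)c2c(O)c(C)c(O)cc2o1` gives 6790 nM, the lowest of the numbers obtained. Compound 3 `CCCCCCCCCCCCCCCc1cc(=O)c2c(O)c(C)c(O)cc2o1`, with a different chain, gives 42800 nM. Among the measured compounds shown here, the only measured step is a 6.3-fold higher number from compound 2 to compound 3 (0.80 log units; beyond the scatter), and it lies in the chain, not on the oxygen. Compound 1 `CCCC/C=C\CCCCCCCCCc1cc(=O)c2c(O)c(C)c(OCOC)cc2o1`, which bears methoxymethoxy on another chain, reads > 87000 nM, and this is a limit of the assay. Compound 4 `CC/C=C\C/C=C\C/C=C\CCCCCCCc1cc(=O)c2c(O)c(C)c(OCOC)cc2o1` keeps the chain of compound 2 and swaps hydroxy for methoxymethoxy: methoxymethyl in place of hydrogen on an oxygen on an aromatic ring. For the measured compounds named here, no measured step covers this change, so weaker inhibition is expected on the evidence of compound 1 alone, which reaches (the limit of > 87000 nM in this assay, at which 1 of the 3 values shown sits). The expected change is a 5.9-fold higher number from compound 2 to compound 4 (0.77 log units; beyond the scatter). For compound 4 the estimated value is 40000 nM, with an expected range of 13000 nM to 120000 nM.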

Compound 4, half-maximal inhibitory concentration: 6790 nM
Estimate against measurement, compound 4: 5.9-fold (0.77 log units) above; the whole stated range lies above it.
By their numbers in this assay, from the lowest: compounds 2 and 4 (each within the scatter of the next); then compound 3. At a limit, above all of these: compound 1.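

In this assay, methoxymethyl in place of hydrogen on an oxygen on an aromatic ring brings no change at the digits printed from compound 2 to compound 4 (within the scatter), so with the chain of compound 2 this change costs nothing. With methoxymethoxy held constant, the chain alone brings an at least 12-fold lower number from compound 1 to compound 4 (1.10 log units; beyond the scatter), so the weak reading of compound 1 cannot be laid on methoxymethoxy. The reading of compound 1 is a limit, not a number: the limit of > 87000 nM in this assay, at which 1 of the 4 values shown sits.

On these data alone, whether a benzyl or acetyl group on this oxygen fares the same stays open. So does whether methoxymethoxy is equally neutral on the saturated chain of compound 3.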